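A Cyclohexyl Group on the Nitrogen of Compound 3

A few compounds are considered here, and "the series" means these few. Any claim that something is new, unique, unknown or untested is made for them only; others in the source may bear on it.

Compound 3 (`CNc1cc(Cl)c(C(=O)Nc2ccc(O)c(C(C)(C)C)c2)c(Cl)c1`) stands at a limit and not at a number: in an ADME assay on a cell-free system (serum) for metabolic stability (a lower number here means that the compound disappears faster, a higher number that the compound lasts longer), compound 3 gives > 1 h as its reading. Compound 1 (`CC(C)(C)c1cc(NC(=O)c2c(Cl)cc(N)cc2Cl)ccc1O`) gives > 1 h in this assay as a limit too. Compound 2 (`CC(C)(C)c1cc(NC(=O)c2c(Cl)cc(NCc3cccs3)cc2Cl)ccc1O`) gives > 1 h in this assay as a limit too. The data therefore hold only the limit of > 1 h in this assay, at which 3 of the 3 values shown sit, and no number.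

Compound 4 (`CN(c1cc(Cl)c(C(=O)Nc2ccc(O)c(C(C)(C)C)c2)c(Cl)c1)C1CCCCC1`) differs from compound 3 by cyclohexyl in place of hydrogen on a nitrogen on an aromatic ring in the form of cyclohexyl in place of hydrogen on a nitrogen on an aromatic ring, so that methylamino becomes cyclohexyl(methyl)amino. Among the measured compounds shown here, three measured steps touch that nitrogen, namely a step that the two limits leave unreadable from compound 1 to compound 3 and a step that the two limits leave unreadable from compound 1 to compound 2 and a step that the two limits leave unreadable from compound 2 to compound 3 with no size to be read from any of them. For the measured compounds named here, no measured compound has two groups other than hydrogen on that nitrogen. The expectation of no clear change rests on a step that the two limits leave unreadable from compound 1 to compound 2 in which (thiophen-2-yl)methyl in place of hydrogen left the reading at the limit. The expected step is a step that the limit leaves unreadable from compound 3 to compound 4 in no particular direction, and nothing beyond the usual scatter is expected. Compound 4 is estimated at 1.5 h with an expected range from 0.7 h to 4 h in this assay and quite possibly only a limit again.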

Compound 4, half-life: > 1 h
Compound 4 ended at the assay's limit; the forecaster's own chance of this, stated with the estimate: 80%; the middle value does not contradict the limit.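

In this assay compound 4 gives > 1 h, which is a limit and not a number. Among the compounds shown here, no step from compound 1, compound 2 or compound 3 to compound 4 can be read, because the data hold only one reading: the limit of > 1 h in this assay, at which 4 of the 4 values shown sit. The compounds shown leave open how long any of them actually lasts, and so whether any change on that nitrogen alters the half-life at all.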